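The source may hold more compounds than are shown below. What is called first, only, known or untested is meant among the compounds shown, and "the series" means these compounds.

Measured in an ADME assay on cells (Bone marrow cell, Homo sapiens) for cytotoxicity, read by luminescence and CellTiter-Glo, with a stated time of 3 days; on this read-out higher numbers stand for weaker inhibition and lower numbers for stronger inhibition:
- compound 1 `O=C(Nc1cc(C(F)(F)F)cc(C(F)(F)F)c1)c1cc(Br)c(-c2ccccc2)cc1O`: > 10000 nM
- compound 2 `N#Cc1ccc(NC(=O)c2ccc3cccnc3c2O)cc1`: 3070 nM

Compound 1 gives only a limit, > 10000 nM, and not a number. Compound 3 `O=C(Nc1cc(C(F)(F)F)cc(C(F)(F)F)c1)c1cc(Br)ccc1O` keeps the core of compound 1 but has hydrogen in place of phenyl on an aromatic carbon. Within the data shown here, no measured pair shows what this change does, so any forecast is uncertain. Compound 2, at 3070 nM, does show that a real number can be read in this assay. The expected step is an at least 3.3-fold lower number from compound 1 to compound 3 (0.52 log units; beyond the scatter), toward stronger inhibition. The estimate for compound 3 is 3000 nM, with an expected range from 600 nM to 12000 nM.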

Compound 3, half-maximal inhibitory concentration: > 10000 nM
Compound 3: a limit, no number; the forecaster's own chance of this, stated with the estimate: 25%; at least 3.3-fold (0.52 log units) between middle value and limit.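

No step can be read from compound 1 to compound 3, because each gives only a limit and not a number: the limit of > 10000 nM in this assay, at which 2 of the 3 values shown sit.

The compounds shown leave open whether hydrogen in place of phenyl changes the read-out at all.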